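The source may report more compounds than this note shows. Statements on the series, on what has been measured and on what is new or still open speak of the compounds shown alone.

Measured so far:
- compound 1 `COc1cc(Cl)cc(-c2nn(-c3cccc(NC(=O)c4ccc(Cl)c(Cl)c4)c3)cc2-c2ccncc2)c1`: 80.1%
- compound 2 `O=C(Nc1cccc(-n2cc(-c3ccncc3)c(-c3cc(O)cc(Cl)c3)n2)c1)Nc1ccc(Cl)c(C(F)(F)F)c1`: 63.1%
- compound 3 `COc1cc(Cl)cc(-c2nn(-c3cccc(NC(=O)Nc4cc(C(F)(F)F)cc(C(F)(F)F)c4)c3)cc2-c2ccncc2)c1`: 6.84%

In a functional assay on SK-OV-3 cells (Homo sapiens) for inhibition, read by sulforhodamine B assay, with a stated time of 48 h, tested at 10 uM (on this read-out higher numbers stand for a weaker effect at the one concentration tested and lower numbers for a stronger effect), compound 1 gives 80.1%, the highest of the three numbers; compound 2 stands a distance beyond the scatter lower, and compound 3 a distance far beyond the scatter lower still. For the measured compounds named here, no two of the measured compounds differ in a single place, so no step between them can be isolated.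

Compound 4 `COc1cc(Cl)cc(-c2nn(-c3cccc(NC(=O)Nc4ccc(Cl)c(Cl)c4)c3)cc2-c2ccncc2)c1` is not yet measured. It differs from compound 1 in one place: (3,4-dichlorophenyl)amino in place of 3,4-dichlorophenyl on a carbonyl carbon. The same change, cut one bond further out, reads (3,4-dichlorophenyl)carbonyl to (3,4-dichlorophenyl)carbamoyl. Compound 4 thus shares the carbamoyl linkage of compounds 2 and 3, while keeping the ring substituents of compound 1. Compound 2 gives 63.1%. Compound 3 gives 6.84%.

Given that, a fall in the read-out from compound 1 to compound 4 is expected, of the size a number 42.1 percentage points lower from compound 1 to compound 4 (beyond the scatter), beyond the scatter. For compound 4 the estimate is 38%, with a range from 10% to 70%; the wide range reflects the absence of any directly comparable pair among the measured compounds.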

Compound 4, a percentage reported as activity, at one concentration (the size of the read-out at that concentration, not a potency): 14.2%
Compound 4: middle estimate off by 23.8 percentage points, on the high side; the measured number falls inside the stated range.
By their numbers in this assay, from the lowest: compounds 3 and 4 (each within the scatter of the next); then compound 2; then compound 1.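

In this assay, for the compounds shown here, (3,4-dichlorophenyl)amino in place of 3,4-dichlorophenyl on a carbonyl carbon gives a number 65.9 percentage points lower from compound 1 to compound 4 (beyond the scatter) and is the first change that can be read on its own. The earlier compounds shown here differed in more than one place, whereas this pair shows that the read-out at this position responds strongly to the change from (3,4-dichlorophenyl)carbonyl to (3,4-dichlorophenyl)carbamoyl, with the 3,4-dichlorophenyl group and the rest of the core of compound 1 kept. No measurement at hand explains the step.

Still open, as far as these compounds go, is whether the nitrogen of the amino link is itself required: an oxygen in its place, giving a carbamate, or a methylene, giving a 3,4-dichlorophenylacetamide, would separate that question on the same core. Going by these compounds alone, also open is whether a step of this size carries over to other aryl groups on the same carbonyl carbon, such as a 3-pyridyl ring, since only this one pair isolates the change and a read-out at one concentration gives no potency.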